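This account rests on a few compounds, and the source may have more. Where it says the series, first, only, none or still open, it means among the compounds named here.

Measured so far:
compound 1 `CSc1nc2cnsc2n1[C@H]1C[C@H](O)[C@@H](CO)O1`: > 100000 nM in a functional assay on HFF cells (Homo sapiens) for inhibition; a lower number here means a stronger inhibitor, a higher number a weaker inhibitor
compound 2 `CSc1nc2c(C)nsc2n1[C@@H]1O[C@H](CO)[C@@H](O)[C@@H]1O`: > 100000 nM in this assay

Compound 1 gives only a limit of this assay, not a number. Compound 2 likewise gives only a limit in this assay, not a number. Among the measured compounds shown here, compound 2 therefore stands where the only other value stands (the limit of > 100000 nM in this assay, at which 2 of the 2 values shown sit).

Compound 3 `CSc1nc2cnsc2n1[C@@H]1O[C@H](CO)[C@@H](O)[C@@H]1O` differs from compound 2 by hydrogen in place of methyl on an aromatic carbon. For the measured compounds named here, no measured step of this kind is available. Because both values sit at the limit (the limit of > 100000 nM in this assay, at which 2 of the 2 values shown sit), no step beyond the scatter is expected. Compound 3 is expected to remain at the limit in this assay, estimated at 200000 nM (range 50000 nM to 1000000 nM). The expected step is a step that the limit leaves unreadable from compound 2 to compound 3 in this assay.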

Compound 3, half-maximal inhibitory concentration: > 100000 nM
Compound 3: only a limit was reported (the forecaster's own chance of this, stated with the estimate: 90%); the middle value lies beyond the limit too.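

The steps from compound 2 and from compound 1 to compound 3 cannot be read, as all the values are limits: the limit of > 100000 nM in this assay, at which 3 of the 3 values shown sit.

Left open is how far each compound lies beyond its limit in this assay, and whether the hydrogen, methyl or hydroxy changes make any difference there.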